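The source may hold more compounds than are shown below. What is called first, only, known or untested is meant among the compounds shown, and "the series" means these compounds.

Of the compounds shown here, three have been measured in an ADME assay on MRC5 cells (Homo sapiens) for inhibition, with a stated time of 72 h; on this read-out lower numbers stand for an effect already at smaller amounts and higher numbers for an effect only at larger amounts of compound. Compound 1, with the structure `CO[C@H]1CC[C@H](NC(=O)c2n[nH]cc2NC(=O)c2ccc(N3CCCC3)cc2)CC1`, shows no number in this assay but only a limit, > 50000 nM, which is the limit of > 50000 nM in this assay, at which 1 of the 3 values shown sits. Compound 2, with the structure `COc1cccc(OC)c1C(=O)Nc1c[nH]nc1C(=O)NC1CCCCCC1`, gives 42000 nM in this assay. Compound 3, with the structure `CO[C@H]1CC[C@H](NC(=O)c2n[nH]cc2NC(=O)c2cc3ccccn3n2)CC1`, gives 1000 nM in this assay. Of the two compounds with an actual number, compound 2 therefore stands at the higher one, meaning that its effect on these cells appears only at the larger amounts, while the value of compound 3 lies well apart from it, beyond the scatter of repeated measurements.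

The step considered here leads from compound 2 to compound 4, whose structure is `COc1cccc(OC)c1C(=O)Nc1c[nH]nc1C(=O)NC1CCCCC1` and which has not yet been measured in this assay. The two differ in one place: cyclohexyl in place of cycloheptyl on an amide-type nitrogen. The change removes a single carbon from a saturated ring at the amide nitrogen and leaves everything else untouched.

Within the data shown here, no measured pair in this set shows such a step, so the size of its effect is unknown. Given how small the change is, the step from compound 2 to compound 4 is expected to be a 1.1-fold higher number from compound 2 to compound 4 (0.06 log units; within the scatter), that is, none beyond the scatter. Compound 4 is accordingly estimated at 48000 nM in this assay, with a likely range from 18000 nM to 130000 nM.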

Compound 4, half-maximal effective concentration: 35000 nM
Estimate against measurement, compound 4: 1.4-fold (0.14 log units) above; the measured number falls inside the stated range.
By their numbers in this assay, from the lowest: compound 3; then compounds 4 and 2 (each within the scatter of the next). At a limit, above all of these: compound 1.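

In this assay, among these compounds, compound 2 and compound 4 form the only pair here that differs in one place, so this is the first direct reading of what the ring on the amide-type nitrogen contributes. Cyclohexyl in place of cycloheptyl gives a 1.2-fold lower number from compound 2 to compound 4 (0.08 log units; within the scatter), so the two rings cannot be told apart at this position on these cells, and neither compound gains an effect at small amounts. This holds only for this pair and says nothing yet about other groups at the same place, but it does show that moving between these two saturated carbon rings is not a change that registers in this read-out. Compound 1 gives a limit rather than a number: the limit of > 50000 nM in this assay, at which 1 of the 4 values shown sits.

Still open, going by these compounds, is what a smaller ring such as cyclopentyl, an open chain such as butyl, or a ring carrying an amine would do on the same amide-type nitrogen. Also open, on these data alone, is whether the step from cycloheptyl to cyclohexyl would stay this small with a different group on the other amide of the shared core.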